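A few compounds are considered here, and "the series" means these few. Any claim that something is new, unique, unknown or untested is made for them only; others in the source may bear on it.

Measured in a functional assay on HBL-100 cells (Homo sapiens) for antiproliferative activity, read by sulforhodamine B assay, with a stated time of 48 h; on this read-out lower numbers stand for stronger inhibition of growth and higher numbers for weaker inhibition of growth:
- compound 1 `CCCCCC(C#CC(=O)OC)O/C=C/C(=O)OC`: 1900 nM
- compound 2 `CCC(C#CC(=O)OC)O/C=C/C(=O)OC`: 320 nM
- compound 3 `CCCC(C#CC(=O)OC)O/C=C/C(=O)OC`: 270 nM

Compound 3 sits level with compound 2, with a 1.2-fold lower number from compound 2 to compound 3 (0.07 log units; within the scatter), and both lie clearly under compound 1 . Compound 4 `CCCCCCCCCCC(C#CC(=O)OC)O/C=C/C(=O)OC` changes compound 3 by heptyl in place of hydrogen on a saturated chain carbon, four bonds along the chain from an oxygen on an unsaturated carbon and a triple-bonded carbon. The closest evidence is a 7.0-fold lower number from compound 1 to compound 3 (0.85 log units; beyond the scatter), alongside a 5.9-fold lower number from compound 1 to compound 2 (0.77 log units; beyond the scatter). Read backwards, these modest steps tie a longer chain to a higher number, although the single methyl between compound 2 and compound 3 shows no such change. Heptyl is a larger addition than either group in those steps, so a rise of similar or greater size is expected in this assay, meaning weaker inhibition of growth. The expected change is a 15-fold higher number from compound 3 to compound 4 (1.17 log units; beyond the scatter). Compound 4 is estimated at 4000 nM ( range 1000 nM to 20000 nM) .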

Compound 4, concentration for 50% growth inhibition: 2200 nM
The estimate for compound 4 lay 1.8-fold (0.26 log units) above the measured number; the range from low to high includes it.
By their numbers in this assay, from the lowest: compounds 3 and 2 (each within the scatter of the next); then compounds 1 and 4 (each within the scatter of the next).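

At this position the gain in chain length carries a real cost: heptyl in place of hydrogen gives an 8.1-fold higher number from compound 3 to compound 4 (0.91 log units; beyond the scatter), and octyl in place of hydrogen gives a 6.9-fold higher number from compound 2 to compound 4 (0.84 log units; beyond the scatter), meaning weaker inhibition of growth. Adding pentyl, however, gives a 1.2-fold higher number from compound 1 to compound 4 (0.06 log units; within the scatter), so among these compounds the number stops rising once the chain is already long. No measurement shown explains this levelling.

Still open, going by these compounds, is how the number behaves at chain lengths between these, and whether an amine or a carboxylic acid in place of the chain would keep the lower numbers.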